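The source may hold more compounds than are shown below. What is called first, only, known or untested is meant among the compounds shown, and "the series" means these compounds.

Measured so far in an ADME assay on MDCK cells (Canis lupus familiaris) for cytotoxicity, read by microscopy; a higher number here means that more compound is tolerated, a lower number that less compound is tolerated:
compound 1 `CSc1nc(-c2ccccc2)c(C#N)c(N2CCN(c3ccnc4cc(Cl)ccc34)CC2)n1`: > 100000 nM
compound 2 `CSc1nc(NCCCCNc2ccnc3cc(Cl)ccc23)c(C#N)c(-c2cccc([N+](=O)[O-])c2)n1`: 20000 nM
compound 3 `CSc1nc(-c2ccc([N+](=O)[O-])cc2)c(C#N)c(N2CCN(c3ccnc4cc(Cl)ccc34)CC2)n1`: > 100000 nM

The value of compound 1 in this assay is a limit of the assay, not a number. The value of compound 3 in this assay is likewise a limit. Compound 2 is thus the only one of the three with an actual number in this assay; the other two sit at a limit, and the limit of > 100000 nM in this assay, at which 2 of the 3 values shown sit, describes where they sit. Among the measured compounds shown here, the one step between measured compounds that differ in a single place, a step that the two limits leave unreadable from compound 1 to compound 3, cannot be read in size, since both of its ends are limits.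

Compound 4 `COc1ccc(-c2nc(SC)nc(NCCCCNc3ccnc4cc(Cl)ccc34)c2C#N)cc1OC` is not yet measured. It differs from compound 2 in one place: 3,4-dimethoxyphenyl in place of 3-nitrophenyl on an aromatic carbon. No measured step involves this exchange, and the single readable-looking step gives no size, so nothing shown points to a direction for the number. The expected step in this assay is therefore a 1.3-fold higher number from compound 2 to compound 4 (0.10 log units; within the scatter), meaning no change beyond the usual scatter. The estimate for compound 4 in this assay is 25000 nM, with a range from 8000 nM to 100000 nM.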

Compound 4, minimum cytotoxic concentration: 20000 nM
For compound 4 the middle estimate is 1.3-fold (0.10 log units) above the measured one, and the stated range covers the measured number.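

In this assay, putting 3,4-dimethoxyphenyl in place of 3-nitrophenyl on the aromatic carbon ortho to a cyano group gives no change at the digits printed from compound 2 to compound 4 (within the scatter). On this core, then, a phenyl group carrying a nitro group and one carrying two methoxy groups are tolerated alike by the cells, even though the two groups differ in their atoms and the entering one has no nitrogen. This is also the first step of the series whose size can be read at all, since the step from compound 1 to compound 3 has a limit at both ends: the limit of > 100000 nM in this assay, at which 2 of the 4 values shown sit.

This single pair cannot say whether the position stays this indifferent to other groups, such as a phenyl ring carrying an amine or a carboxylic acid, or a simple methyl group in place of the whole ring. It also leaves open whether a longer chain on the core of compound 2 would shift the number, and whether the same exchange on the core of compound 1 would give a readable value.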